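Stretching the methyl of compound 2 into a hexyl chain

This account rests on a few compounds, and the source may have more. Where it says the series, first, only, none or still open, it means among the compounds named here.

In a functional assay on MDA-MB-231 cells (Homo sapiens) for antiproliferative activity, with a stated time of 4 days (a higher number here means a weaker inhibitor, a lower number a stronger inhibitor), compound 1 (`COc1ccc(-c2[nH]c3cc(OC)ccc3c2C=C(C#N)C#N)cc1`) gives 260 nM and compound 2 (`COc1ccc(-c2[nH]c3ccc(C)cc3c2C=C(C#N)C#N)cc1`) gives 280 nM, so these two stand level within the scatter. Compound 3 (`COc1ccc(-c2[nH]c3cc(Cl)c(C)cc3c2C=C(C#N)C#N)cc1`) gives 75 nM, which leaves compound 2 among the higher numbers of the small set.

Compound 4 (`CCCCCCc1ccc2[nH]c(-c3ccc(OC)cc3)c(C=C(C#N)C#N)c2c1`) has not yet been measured in this assay. It departs from compound 2 by pentyl in place of hydrogen on a saturated chain carbon bound to an aromatic carbon, which turns methyl into hexyl.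

For the measured compounds named here, no measured step lengthens a chain, so the data offer no direct guide. Going by the values given here, the only step available, a 3.7-fold lower number from compound 2 to compound 3 (0.57 log units; beyond the scatter), is chloro in place of hydrogen on an aromatic carbon, and it serves solely as a gauge of size. On that gauge a modest change is expected, and the direction remains a cautious guess towards a higher number. The expected change is a 2.1-fold higher number from compound 2 to compound 4 (0.33 log units; beyond the scatter). For compound 4 the estimated value is 600 nM, with an expected range of 150 nM to 2500 nM.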

Compound 4, half-maximal inhibitory concentration: 46 nM
The estimate for compound 4 lay 13-fold (1.12 log units) above the measured number; the whole stated range lies above it.
By their numbers in this assay, from the lowest: compounds 4 and 3 (each within the scatter of the next); then compounds 1 and 2 (each within the scatter of the next).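

Turning methyl into hexyl gives a 6.1-fold lower number from compound 2 to compound 4 (0.78 log units; beyond the scatter), so in this assay the saturated chain carbon bound to an aromatic carbon can carry a pentyl extension while the number still falls. For the compounds shown here, until now the only step beyond the scatter was a 3.7-fold lower number from compound 2 to compound 3 (0.57 log units; beyond the scatter), a chloro change on an aromatic carbon; this new step shows that lengthening a chain, with no ring and no hydrogen-bond donors or acceptors added, also lowers the number. Nothing measured here accounts for this drop.

As far as these compounds go, with only methyl and hexyl at this place, the chain lengths between them, a longer chain such as octyl, and a chain ending in an amine or a carboxylic acid all remain open. From the compounds shown here alone, whether the chloro of compound 3 and the hexyl of compound 4 would add up in one molecule is also open.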